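A Benzyloxy Group Added to the Aryl Ring

The source may report more compounds than this note shows. Statements on the series, on what has been measured and on what is new or still open speak of the compounds shown alone.

Compound 2 `COCCC1CN(c2ccccc2)NC1=O` holds the lower of the two numbers measured in a physicochemical assay for lipophilicity; a lower number here means a more polar compound, a higher number a more lipophilic compound: compound 2 gives 0.53, while compound 1 `COCCOCC1CN(c2ccccc2)NC1=O` gives 0.955, a step of a number 0.43 log units lower from compound 1 to compound 2 (beyond the scatter). Compound 3 `COCCC1CN(c2ccc(OCc3ccccc3)cc2)NC1=O` differs from compound 2 in one place: benzyloxy in place of hydrogen on an aromatic carbon. Going by the values given here, the only measured step concerns a chain on the saturated ring and does not bear on this change, so no measured step guides the expectation. Compound 3 is nonetheless expected to give a clearly higher number, estimated at 2.2, within 1.7 to 2.7. The expected step is a number 1.67 log units higher from compound 2 to compound 3 (beyond the scatter).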

Compound 3, partition coefficient: 2.22
Estimate against measurement, compound 3: 0.02 log units below; the measured number falls inside the stated range.
By their numbers in this assay, from the lowest: compound 2; then compound 1; then compound 3.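

Going by these compounds alone, compound 3 gives the first reading for a change on the aromatic carbon rather than on the chain at the saturated ring: benzyloxy in place of hydrogen brings a number 1.69 log units higher from compound 2 to compound 3 (beyond the scatter) in this assay. This step is large, while the chain change gave a modest one, a number 0.43 log units lower from compound 1 to compound 2 (beyond the scatter), in the same assay. Nothing available accounts for the size of the step at this position.

Going by these compounds, whether the whole benzyloxy group or only its aromatic ring sets this size remains open. So does how a methoxy group, an amine or a carboxylic acid on the same aromatic carbon would read in this assay.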